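The source may report more compounds than this note shows. Statements on the series, on what has been measured and on what is new or still open speak of the compounds shown alone.

- Compound 1 `COc1cc(C(=O)c2sc3ccccc3c2-c2ccc(F)cc2)cc(OC)c1OC`: 3200 nM
- Compound 2 `COc1cc(C(=O)c2sc3ccccc3c2Nc2ccc(C)cc2)cc(OC)c1OC`: 2600 nM

In a functional assay on A549 cells (Homo sapiens) for antiproliferative activity, read by MTT assay, with a stated time of 72 h (a higher number here means a weaker inhibitor, a lower number a stronger inhibitor), compound 2 gives 2600 nM and compound 1 gives 3200 nM, so the two stand level, with a 1.2-fold lower number from compound 1 to compound 2 (0.09 log units; within the scatter). The next compound, compound 3 `COc1ccc(Nc2c(C(=O)c3cc(OC)c(OC)c(OC)c3)sc3ccccc23)cc1`, keeps the core of compound 2 and has methoxy in place of methyl on an aromatic carbon, para to a large group (methoxy in place of methyl on an aromatic carbon). Going by the values given here, the sole measured step bears on this change only loosely, since it swaps 4-fluorophenyl for (4-methylphenyl)amino and does not test methoxy against methyl. That step, a 1.2-fold lower number from compound 1 to compound 2 (0.09 log units; within the scatter), gives no reason to expect a large shift in either direction, so little beyond the scatter is expected, though with wide uncertainty. The step expected is a 1.4-fold lower number from compound 2 to compound 3 (0.16 log units; within the scatter). For compound 3 the estimated value is 1800 nM, with an expected range from 300 nM to 5000 nM.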

Compound 3, half-maximal inhibitory concentration: 9300 nM
For compound 3 the middle estimate is 5.2-fold (0.71 log units) below the measured one; measured number above the stated range.
By their numbers in this assay, from the lowest: compounds 2 and 1 (each within the scatter of the next); then compound 3.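

In this assay, this place, on an aromatic carbon para to a large group, proves sensitive to the group it carries: methoxy in place of methyl gives a 3.6-fold higher number from compound 2 to compound 3 (0.55 log units; beyond the scatter), a sensitivity that the level pair of compound 1 and compound 2 gave no sign of. Measured against the 4-fluorophenyl group, the (4-methoxyphenyl)amino group gives a 2.9-fold higher number from compound 1 to compound 3 (0.46 log units; beyond the scatter), whereas the (4-methylphenyl)amino group of compound 2 stood level with it, so the outcome of that swap depends on the group at the far end of the ring. Nothing among the data offers an explanation for this step.

A single pair cannot tell whether the added oxygen or the longer substituent matters here. As far as these compounds go, it remains open whether a hydroxyl, an ethyl or a chlorine at this place would stay level with methyl or follow methoxy.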